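This account rests on a few compounds, and the source may have more. Where it says the series, first, only, none or still open, it means among the compounds named here.

Three compounds that share a four-carbon chain linking two aromatic rings have been measured in an ADME assay on the whole organism for metabolic stability, with Rattus norvegicus as the target, at a dose of 10 mg/kg by the intraperitoneal route; on this read-out lower numbers stand for a shorter-lived compound and higher numbers for a longer-lived compound. Compound 1, `COc1cc(C(=O)O)ccc1OCCCCOc1ccc(C(=O)CC(C)C)c(O)c1C`, gives 0.717 h in this assay. Compound 2, `CCC(=O)c1ccc(OCCCCOc2ccc(F)c(C(=O)O)c2)c(C)c1O`, gives 0.367 h, and compound 3, `Cc1c(OCCCCOc2ccc(F)c(C(=O)O)c2)ccc(C(=O)C(C)C)c1O`, gives 0.5 h. Compounds 2 and 3 differ by methyl in place of hydrogen on a saturated chain carbon bound to a carbonyl carbon and a saturated chain carbon, and this assay reads a 1.4-fold higher number from compound 2 to compound 3 (0.13 log units; within the scatter). Compound 1 and compound 2 differ in more than one place, so the difference between their cores is not broken down here.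

Compound 4, `COc1cc(C(=O)O)ccc1OCCCCOc1ccc(C(=O)CC(C)(C)C)c(O)c1C`, has not yet been measured. It differs from compound 1 by methyl in place of hydrogen on a saturated chain carbon bound to three saturated chain carbons. Within the data shown here, this is the same kind of change as the one from compound 2 to compound 3, but at a different surrounding: there the carbon that gains the methyl is bound to a carbonyl carbon and a saturated chain carbon, whereas here it is bound to three saturated chain carbons. Resting on the small change seen in a 1.4-fold higher number from compound 2 to compound 3 (0.13 log units; within the scatter), a step of about a 1.2-fold higher number from compound 1 to compound 4 (0.07 log units; within the scatter) is expected from compound 1 to compound 4 in this assay. Compound 4 is therefore estimated to give 0.85 h in this assay, within a range from 0.4 h to 1.8 h.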

Compound 4, half-life: 2.2 h
The estimate for compound 4 lay 2.6-fold (0.41 log units) below the measured number, and the stated range ends below it.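

In this assay, the methyl that turns the isobutyl group of compound 1 into the neopentyl group of compound 4 gives a 3.1-fold higher number from compound 1 to compound 4 (0.49 log units; beyond the scatter), a step larger than repeated measurements would normally produce. Set beside the same change on the other core, this step points the same way, and the gap between the two is no larger than the scatter allows: the same change on two cores in this assay, a 1.4-fold higher number (0.13 log units; within the scatter) from compound 2 to compound 3 and a 3.1-fold higher number (0.49 log units; beyond the scatter) from compound 1 to compound 4, 2.3-fold (0.35 log units) apart, within the scatter of two such steps. Among these compounds, this means the data give no sign that the core alters the effect of this change, but they do not prove that the effect carries over at the same size, since there are only two pairs, the earlier step alone lies within the scatter, and the carbon gaining the methyl has different surroundings in each pair.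

The compounds shown leave open how a longer chain or a cyclopropyl group at this end of the molecule would read in this assay. They also leave open whether an amine or an amide in place of the carboxylic acid would alter the step.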